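The compounds below may be only part of what the source reports. "The series", "measured", "known", "first", "only" and "open" are said of these compounds alone.

Measured so far:
compound 1 `COc1cc(-c2cc(/C=C/C(=O)c3ccc(Cl)c(Cl)c3)[nH]n2)cc(OC)c1OC` — 92%
compound 2 `COc1ccc(-c2cc(/C=C/C(=O)c3ccc(N)cc3)[nH]n2)cc1OC` — 94%
compound 3 `COc1ccc(-c2cc(/C=C/C(=O)c3cc(OC)c(OC)c(OC)c3)[nH]n2)cc1OC` — 81%

All three were tested in a functional assay on OVCAR-5 cells (Homo sapiens) for cytotoxicity, read by sulforhodamine B assay, with a stated time of 48 h, tested at 1 uM; on this read-out lower numbers stand for a stronger effect and higher numbers for a weaker effect at the one concentration tested. Compound 1 gives 92%, which stands second highest of the three numbers. Compound 2 gives 94%, a value within the usual scatter of that of compound 1, so the two cannot be told apart on this read-out. Compound 3 gives 81%, which lies below the value of compound 1 by a gap beyond the usual scatter, the only clear separation within this small set. All three values sit in the range that marks a weak effect at the single concentration tested.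

Compound 4 `COc1ccc(C(=O)/C=C/c2cc(-c3cc(OC)c(OC)c(OC)c3)n[nH]2)cc1OC` has not yet been measured. It differs from compound 1 in one place: 3,4-dimethoxyphenyl in place of 3,4-dichlorophenyl on a carbonyl carbon. Among the measured compounds shown here, no step between two measured compounds that differ in one place is available to calibrate this change, so the expectation rests on the spread of the three values alone. For the measured compounds named here, since compound 3, the one measured compound that carries a 3,4-dimethoxyphenyl group, gives 81%, a modest downward step from compound 1 to compound 4 is expected, of a size near the edge of the scatter, namely a number 5 percentage points lower from compound 1 to compound 4 (within the scatter). Compound 4 is therefore estimated to give 87%, with a range from 74% to 98%.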

Compound 4, a percentage reported as activity, at one concentration (the size of the read-out at that concentration, not a potency): 86%
Compound 4: middle estimate off by 1 percentage points, on the high side; measured number inside the range.
By their numbers in this assay, from the lowest: compounds 3, 4, 1 and 2 (each within the scatter of the next, the first and the last beyond it).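

Among the compounds shown here, this is the first pair in the set that differs in one place, so the change on a carbonyl carbon can now be read directly in this assay: 3,4-dimethoxyphenyl in place of 3,4-dichlorophenyl gives a number 6 percentage points lower from compound 1 to compound 4 (within the scatter). The entering group is larger than the leaving one and carries hydrogen-bond acceptors that the leaving group lacks, yet this exchange of substituents on the phenyl ring does not separate the two compounds on this read-out, so at this position and at the one concentration tested, chlorine and methoxy substituents cannot be told apart. No supporting measurement bears on this result.

The compounds shown leave open whether a different kind of group on the same carbonyl carbon, such as a carboxylic acid or a morpholine, would give a step beyond the usual scatter. They also leave open whether compound 1 and compound 4 would separate at other concentrations, since a single concentration gives the size of the read-out and not a potency.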